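Removing one fluorine from a trifluorobenzyl cytotoxicity series

This account rests on a few compounds, and the source may have more. Where it says the series, first, only, none or still open, it means among the compounds named here.

Three compounds with a shared core carry differently fluorinated benzyl groups on the aromatic nitrogen. In an ADME assay on MT4 cells (Homo sapiens) for cytotoxicity, read by MTT assay (on this read-out higher numbers stand for lower toxicity in this test and lower numbers for higher toxicity in this test), compound 1 `CCOC(=O)/C(O)=C/C(=O)c1cn(Cc2cc(F)c(F)c(F)c2)c2cccc(OC)c12` gives 33400 nM, compound 2 `CCOC(=O)/C(O)=C/C(=O)c1cn(Cc2cc(F)cc(F)c2)c2cccc(OC)c12` gives 34700 nM, and compound 3 `CCOC(=O)/C(O)=C/C(=O)c1cn(Cc2c(F)ccc(F)c2F)c2cccc(OC)c12` gives 40500 nM. The change from compound 1 to compound 2 is hydrogen in place of fluoro on an aromatic carbon and makes a 1.0-fold higher number from compound 1 to compound 2 (0.02 log units; within the scatter). Between compound 1 and compound 3 the difference is 2,3,6-trifluorophenyl in place of 3,4,5-trifluorophenyl on a saturated chain carbon bound to an aromatic nitrogen, with a 1.2-fold higher number from compound 1 to compound 3 (0.08 log units; within the scatter); the remaining pair shows a 1.2-fold higher number from compound 2 to compound 3 (0.07 log units; within the scatter).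

Compound 4 `CCOC(=O)/C(O)=C/C(=O)c1cn(Cc2cc(F)ccc2F)c2cccc(OC)c12` is not yet measured in this assay. It differs from compound 3 by hydrogen in place of fluoro on an aromatic carbon. This is the same kind of change as from compound 1 to compound 2, but the surroundings differ: there the leaving fluoro was ortho to two fluoro groups and para to a large group, here it is ortho to a fluoro group, ortho to a large group and meta to a fluoro group. Because the earlier step was a 1.0-fold higher number from compound 1 to compound 2 (0.02 log units; within the scatter), compound 3 to compound 4 is expected to show a 1.0-fold higher number from compound 3 to compound 4 (0.02 log units; within the scatter). Compound 4 is therefore estimated at 42000 nM, likely between 25000 nM and 70000 nM.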

Compound 4, half-maximal cytotoxic concentration: 41200 nM
The estimate for compound 4 lay 1.0-fold (0.01 log units) above the measured number; the range from low to high includes it.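

In this assay, hydrogen in place of fluoro gives a 1.0-fold higher number from compound 3 to compound 4 (0.01 log units; within the scatter), and the exchange reads the same on both fluorinated benzyl patterns: the same change on two cores in this assay, a 1.0-fold higher number (0.02 log units; within the scatter) from compound 1 to compound 2 and a 1.0-fold higher number (0.01 log units; within the scatter) from compound 3 to compound 4, 1.0-fold (0.01 log units) apart, within the scatter of two such steps. The two other new comparisons, with the 2,5-difluorophenyl group in place of the 3,5-difluorophenyl and 3,4,5-trifluorophenyl groups, also stay inside the scatter, as a 1.2-fold higher number from compound 2 to compound 4 (0.07 log units; within the scatter) and a 1.2-fold higher number from compound 1 to compound 4 (0.09 log units; within the scatter). This shows that, across these four compounds, removing this fluoro left no readable mark on either background, but it does not show that a real effect carries from one core to another, since a step within the scatter gives nothing of measurable size to transfer, and two pairs cannot establish a rule.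

The compounds shown leave open whether a chloro group or an amine on the benzyl ring would shift the number beyond the scatter. They also leave open whether a carboxylic acid in place of the ethyl ester would do so.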